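Swapping a Carboxylic Acid for Chlorine on Compound 1

The source may report more compounds than this note shows. Statements on the series, on what has been measured and on what is new or still open speak of the compounds shown alone.

Measured compounds:
- compound 1 `Cn1c(-c2ccc(C(=O)O)cc2)nc2c(NC3CCCC3)ncnc21`: 54000 nM
- compound 2 `CCn1c(-c2ccccc2)nc2c(N)ncnc21`: 31 nM

In an assay on CHO cells for displacement of a labelled ligand from adenosine receptor A1 (Homo sapiens), read by scintillation counting, with a stated time of 3 h (on this read-out higher numbers stand for weaker inhibition and lower numbers for stronger inhibition), compound 1 gives 54000 nM, the highest of the two numbers and far beyond the scatter from compound 2, which gives 31 nM in this assay. The two compounds differ in several places, so no single change can be held responsible for that gap.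

Compound 3 `Cn1c(-c2ccc(Cl)cc2)nc2c(NC3CCCC3)ncnc21` follows from compound 1 by one change: chloro in place of carboxy on an aromatic carbon. Among the compounds with values here, no measured pair shows exactly this step, so the expectation rests on the fact that compound 2, which carries no carboxy group, reaches 31 nM in this assay while compound 1 stands at 54000 nM. The step from compound 1 to compound 3 is expected to be a 360-fold lower number from compound 1 to compound 3 (2.56 log units; beyond the scatter), a large move toward stronger inhibition. Compound 3 is estimated at 150 nM, within a range from 15 nM to 1500 nM.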

Compound 3, inhibition constant: 18 nM
The estimate for compound 3 lay 8.3-fold (0.92 log units) above the measured number; measured number inside the range.
By their numbers in this assay, from the lowest: compounds 3 and 2 (each within the scatter of the next); then compound 1.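

In this assay, within the data shown here, putting chloro in place of carboxy gives a 3000-fold lower number from compound 1 to compound 3 (3.48 log units; beyond the scatter) and so goes beyond what the earlier compounds could show. Those two compounds differ in several places, whereas this pair differs in one, which ties a large move toward stronger inhibition to this single position on the six-membered aromatic ring. Nothing at hand tells why the swap has such an effect.

On these data alone, it remains open whether the large change follows from removing the carboxy group or from adding chloro in particular, and a fluoro, methoxy or primary amide group at the same carbon would help separate those two readings. As far as these compounds go, it is also open whether the same swap would produce a similar step if other parts of the core of compound 1 were changed.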